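From 4-hydroxyphenyl to 3,4-dichlorophenyl: an unmeasured step

The source may hold more compounds than are shown below. What is called first, only, known or untested is meant among the compounds shown, and "the series" means these compounds.

- Compound 1 `COc1ccc(/C=C2\CCC/C(=C\c3ccccc3Cl)C2=O)cc1OC`: 7100 nM
- Compound 2 `COc1ccc(/C=C2\CCC/C(=C\c3ccc(Br)cc3)C2=O)cc1OC`: 5200 nM
- Compound 3 `COc1ccc(/C=C2\CCC/C(=C\c3ccc(O)cc3)C2=O)cc1OC`: 7700 nM

All three numbers come from a functional assay on SW-620 cells (Homo sapiens) for cytotoxicity, read by MTT assay, with a stated time of 72 h; a lower number here means a stronger inhibitor, a higher number a weaker inhibitor. Compound 3 stands level with the other two, as the steps that reach it show: a 1.1-fold higher number from compound 1 to compound 3 (0.04 log units; within the scatter) and a 1.5-fold higher number from compound 2 to compound 3 (0.17 log units; within the scatter).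

Compound 4 `COc1ccc(/C=C2\CCC/C(=C\c3ccc(Cl)c(Cl)c3)C2=O)cc1OC` carries 3,4-dichlorophenyl in place of 4-hydroxyphenyl on a double-bonded chain carbon bound to a double-bonded ring carbon.

The measured steps that bear on this change swap groups at this same place. Besides the two above, there is a 1.4-fold lower number from compound 1 to compound 2 (0.14 log units; within the scatter). All three are small, although the groups differ. Among the measured compounds shown here, no compound with a 3,4-dichlorophenyl group has been measured yet, so this evidence is indirect. A step beyond the scatter is therefore not expected in this assay, and the data favour no clear direction. The expected step is a 1.3-fold lower number from compound 3 to compound 4 (0.11 log units; within the scatter). Compound 4 is estimated at 6000 nM, with an expected range of 2800 nM to 13000 nM.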

Compound 4, half-maximal inhibitory concentration: 4000 nM
Compound 4: middle estimate off by 1.5-fold (0.18 log units), on the high side; the range from low to high includes it.
By their numbers in this assay, from the lowest: compounds 4, 2, 1 and 3 (each within the scatter of the next).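

At this place, on a double-bonded chain carbon bound to a double-bonded ring carbon, a phenyl ring with two chlorine atoms gives no step beyond the scatter in this assay (a 1.9-fold lower number from compound 3 to compound 4 (0.28 log units; within the scatter)) and (a 1.3-fold lower number from compound 2 to compound 4 (0.11 log units; within the scatter)) and (a 1.8-fold lower number from compound 1 to compound 4 (0.25 log units; within the scatter)). Among the compounds shown here, removing the hydrogen-bond donor and acceptor of 4-hydroxyphenyl therefore leaves the number within the scatter, and the flat picture now covers all four compounds, with no compound going against it. Nothing measured here offers a reason for this flatness.

From the compounds shown here alone, all four groups at this place are substituted phenyl rings, so it stays open whether an amine, a carboxylic acid or a longer chain there would move the number beyond the scatter. Going by these compounds, whether a change elsewhere on the shared core would do so also stays open.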